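From 3- to 2-(trifluoromethyl)phenyl on a sulfonyl sulfur

A few compounds are considered here, and "the series" means these few. Any claim that something is new, unique, unknown or untested is made for them only; others in the source may bear on it.

Measured in a functional assay on VCaP cells (Homo sapiens) for antiproliferative activity, read by propidium iodide staining, with a stated time of 96 h; a higher number here means a weaker inhibitor, a lower number a stronger inhibitor:
- compound 1 `CC(O)(CS(=O)(=O)c1ccc(F)cc1)C(=O)Nc1cccc(S(F)(F)(F)(F)F)c1`: 37900 nM
- compound 2 `CC(O)(CS(=O)(=O)c1cccc(C(F)(F)F)c1)C(=O)Nc1cccc(S(F)(F)(F)(F)F)c1`: 35500 nM

Only these two compounds have been measured so far, and compound 2, at 35500 nM, lies within the scatter of compound 1. The next compound is compound 3 `CC(O)(CS(=O)(=O)c1ccccc1C(F)(F)F)C(=O)Nc1cccc(S(F)(F)(F)(F)F)c1`, which has the same atoms as compound 2, joined differently: 2-(trifluoromethyl)phenyl in place of 3-(trifluoromethyl)phenyl on a sulfonyl sulfur. In words, 2-(trifluoromethyl)phenyl stands in place of 3-(trifluoromethyl)phenyl on a sulfonyl sulfur.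

Among the compounds with values here, one measured step bears on this, a swap of the group at the same place: a 1.1-fold lower number from compound 1 to compound 2 (0.03 log units; within the scatter). Within the data shown here, that step is small, but it is the only guide, and no compound carrying 2-(trifluoromethyl)phenyl has a measured value yet. So no change beyond the scatter is expected in this assay.

The expected step is a 1.0-fold lower number from compound 2 to compound 3 (0.01 log units; within the scatter).

Compound 3 is estimated at 35000 nM, with a range of 18000 nM to 65000 nM.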

Compound 3, half-maximal inhibitory concentration: 40800 nM
Compound 3: the middle estimate sits 1.2-fold (0.07 log units) below what was measured; the measured number falls inside the stated range.
By their numbers in this assay, from the lowest: compounds 2, 1 and 3 (each within the scatter of the next).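

Swapping 3-(trifluoromethyl)phenyl for 2-(trifluoromethyl)phenyl on the sulfonyl sulfur gives, in this assay, a 1.1-fold higher number from compound 2 to compound 3 (0.06 log units; within the scatter), so rearranging the same atoms leaves the result within the usual scatter. The comparison with the 4-fluorophenyl group gives a 1.1-fold higher number from compound 1 to compound 3 (0.03 log units; within the scatter), which is also within the scatter, so all three substituted phenyl groups tested at this place give results that cannot be told apart in this assay. Nothing available explains this lack of separation.

All three compounds carry a substituted phenyl ring on the sulfonyl sulfur, so these results say little about very different groups there. Going by these compounds, it remains open whether a phenyl ring bearing an amine or a carboxylic acid, or a saturated cyclohexyl ring in place of the phenyl ring, would shift the number beyond the scatter.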